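The source may report more compounds than this note shows. Statements on the series, on what has been measured and on what is new or still open speak of the compounds shown alone.

In an ADME assay on microsomes from liver (Rattus norvegicus) for metabolic stability, read by LC-MS, using NADPH, with stated times of 10 min and 60 min (a lower number here means slower removal, a higher number faster removal of the compound), compound 1 `CN1CCN(c2cc(CN(C)C3CCCc4cccnc43)nc(N)n2)CC1` gives 767 mL/min/kg and compound 2 `Cc1nc(CN(C)C2CCCc3cccnc32)c(F)c(N2CCN(C)CC2)n1` gives 1080 mL/min/kg within the scatter of compound 1. Compound 3 `Cc1nc(CN(C)C2CCCc3cccnc32)c(C#N)c(N2CCN(C)CC2)n1` differs from compound 2 by cyano in place of fluoro on an aromatic carbon ortho to a 4-methylpiperazin-1-yl group and para to a methyl group. Among the measured compounds shown here, no measured pair shows this change, so a shift beyond the scatter is not expected in this assay and only a slight downward lean is assumed. The expected step is a 1.4-fold lower number from compound 2 to compound 3 (0.13 log units; within the scatter) and stays modest. The estimated value for compound 3 is 800 mL/min/kg in a range from 400 mL/min/kg to 1500 mL/min/kg.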

Compound 3, clearance: 1640 mL/min/kg
Beside the measured number, compound 3's estimate is 2.1-fold (0.31 log units) below it; the measured number lies above the stated range.
By their numbers in this assay, from the lowest: compounds 1, 2 and 3 (each within the scatter of the next, the first and the last beyond it).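

This first pair at the aromatic carbon ortho to a 4-methylpiperazin-1-yl group and para to a methyl group gives, in this assay, a 1.5-fold higher number from compound 2 to compound 3 (0.18 log units; within the scatter) for cyano in place of fluoro. At this position, then, the swap gives no shift beyond the scatter, and the two compounds cannot be ranked on clearance. Nothing available bears on the basis of this result.

As far as these compounds go, whether an amine, a carboxylic acid or a longer chain at this carbon would shift clearance beyond the scatter stays open. Also open, from the compounds shown here alone, is whether cyano in place of fluoro would read the same way on the core of compound 1.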